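Trifluoromethylphenyl amide on the urea-bearing core

A few compounds are considered here, and "the series" means these few. Any claim that something is new, unique, unknown or untested is made for them only; others in the source may bear on it.

Two compounds sharing one core have been examined for antiproliferative activity. Compound 1 `NC(=O)c1c(NC(=O)c2ccc(C(F)(F)F)cc2)sc2c1CCN(Cc1ccccc1F)C2` carries a 4-(trifluoromethyl)phenyl amide together with a 2-fluorobenzyl group on the ring nitrogen; in a functional assay on MKN-74 cells (Homo sapiens) for antiproliferative activity, with a stated time of 24 h (on this read-out lower numbers stand for stronger inhibition and higher numbers for weaker inhibition), compound 1 gives 26900 nM. Compound 2 `NC(=O)c1c(NC(=O)c2ccccc2Cl)sc2c1CCN(C(=O)Nc1ccccc1Cl)C2` carries a 2-chlorophenyl amide and a 2-chlorophenyl urea on the ring nitrogen; in this assay compound 2 gives 16300 nM. Compound 2 has the lower of the two numbers, but the gap to compound 1 lies within the scatter, so the two cannot be told apart.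

Compound 3 `NC(=O)c1c(NC(=O)c2ccc(C(F)(F)F)cc2)sc2c1CCN(C(=O)Nc1ccccc1Cl)C2` keeps the urea of compound 2 and differs from it in one place: 4-(trifluoromethyl)phenyl in place of 2-chlorophenyl on a carbonyl carbon. It thus combines the amide of compound 1 with the ring-nitrogen substituent of compound 2. For the measured compounds named here, no step between measured compounds bears on this change. With compound 1 at 26900 nM and compound 2 at 16300 nM both weak and indistinguishable, no move beyond the scatter is expected from compound 2 to compound 3, which is estimated at a 1.2-fold higher number from compound 2 to compound 3 (0.09 log units; within the scatter). Compound 3 is therefore expected to give about 20000 nM in this assay, with a range from 8000 nM to 50000 nM.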

Compound 3, half-maximal inhibitory concentration: 43900 nM
Beside the measured number, compound 3's estimate is 2.2-fold (0.34 log units) below it, within the range that was stated.
By their numbers in this assay, from the lowest: compounds 2, 1 and 3 (each within the scatter of the next, the first and the last beyond it).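

On the carbonyl carbon whose other neighbours are an amide-type nitrogen, this assay now offers a comparison in one place: with the 2-chlorophenyl urea held fixed, 4-(trifluoromethyl)phenyl in place of 2-chlorophenyl gives a 2.7-fold higher number from compound 2 to compound 3 (0.43 log units; beyond the scatter), a modest step towards weaker inhibition, which shows that the number at this position responds to the aryl group it carries. With the 4-(trifluoromethyl)phenyl amide held fixed, (2-chlorophenyl)carbamoyl in place of 2-fluorobenzyl on an amine nitrogen in a ring gives a 1.6-fold higher number from compound 1 to compound 3 (0.21 log units; within the scatter), so that change cannot be told from the scatter. Nothing measured here accounts for either step.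

What a plain phenyl, a methoxyphenyl or a short alkyl chain would give on this carbonyl carbon stays open, so the compounds shown cannot separate the loss of the chlorine from the arrival of the trifluoromethyl group. For the compounds shown here, it also stays open whether a free amine or an acetyl group on the amine nitrogen in a ring would move the number beyond the scatter, since only two groups can be compared there.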